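A few compounds are considered here, and "the series" means these few. Any claim that something is new, unique, unknown or untested is made for them only; others in the source may bear on it.

Values measured in a functional assay on Huh-7 cells (Homo sapiens) for inhibition, read by MTT assay, with a stated time of 72 h; a higher number here means a weaker inhibitor, a lower number a stronger inhibitor:

Compound 1 `Nc1ncnc2c1c(-c1cnc3[nH]ccc3c1)nn2CCCCCCCCCC(=O)NO`: 10100 nM
Compound 2 `Nc1nc2cc(-c3nn(CCCCC(=O)NO)c4ncnc(N)c34)ccc2o1`: 9220 nM
Compound 3 `Nc1nc2cc(-c3nn(CCCCCC(=O)NO)c4ncnc(N)c34)ccc2o1`: 9910 nM

Compound 3, at 9910 nM, lies within the usual scatter of both compound 1 and compound 2, so it cannot be ranked against either. The next compound, compound 4 `Nc1nc2cc(-c3nn(CCCCCCC(=O)NO)c4ncnc(N)c34)ccc2o1`, extends the chain of compound 3: (hydroxycarbamoyl)methyl stands in place of hydroxycarbamoyl on a saturated chain carbon, five bonds along the chain from an aromatic nitrogen ((hydroxycarbamoyl)methyl in place of hydroxycarbamoyl on a saturated chain carbon, five bonds along the chain from an aromatic nitrogen).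

For the measured compounds named here, only one measured step bears on this change. The same swap, made on a saturated chain carbon four bonds along the chain from an aromatic nitrogen, gave a 1.1-fold higher number from compound 2 to compound 3 (0.03 log units; within the scatter). One step is a thin basis for a forecast, but it offers no reason to expect a large move in this assay. The expected change is a 1.1-fold lower number from compound 3 to compound 4 (0.04 log units; within the scatter), which would be no real step beyond the scatter. For compound 4 the estimated value is 9000 nM, with an expected range from 4000 nM to 15000 nM.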

Compound 4, half-maximal inhibitory concentration: 5710 nM
Compound 4: the middle estimate sits 1.6-fold (0.20 log units) above what was measured; the range from low to high includes it.
By their numbers in this assay, from the lowest: compounds 4, 2, 3 and 1 (each within the scatter of the next).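

In this assay, adding one more chain carbon at this position, with (hydroxycarbamoyl)methyl in place of hydroxycarbamoyl, gives a 1.7-fold lower number from compound 3 to compound 4 (0.24 log units; within the scatter), so a second extension of the chain also produces no real change. Extending by two carbons in one move, with 2-(hydroxycarbamoyl)ethyl in place of hydroxycarbamoyl, gives a 1.6-fold lower number from compound 2 to compound 4 (0.21 log units; within the scatter), which means that across these three chain lengths on the shared core, the length of the chain has no effect that this assay can separate from its scatter. No measurement available here bears on the result.

As far as these compounds go, it remains open whether a longer chain on this same core would move the number beyond the scatter. Also open, from the compounds shown here alone, is whether a carboxylic acid or a primary amide at the chain end, in place of hydroxycarbamoyl, would change it.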